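Swapping methoxy for fluoro on a brain-tumour cell assay

The compounds below may be only part of what the source reports. "The series", "measured", "known", "first", "only" and "open" are said of these compounds alone.

Three compounds built on a shared core were tested in a functional assay on SNB-19 cells (Homo sapiens) for inhibition, read by sulforhodamine B assay, with a stated time of 48 h; on this read-out lower numbers stand for stronger inhibition of growth and higher numbers for weaker inhibition of growth. Compound 1, `COc1ccc(-c2ccc(-c3ccc(C(=N)N)o3)o2)cc1`, gives 1990 nM in this assay. Compound 2, `N=C(N)c1ccc(-c2ccc(-c3cncc4ccccc34)s2)s1`, gives 2170 nM, and compound 3, `COc1cc(OC)cc(-c2ccc(-c3ccc(C(=N)N)o3)o2)c1`, gives 3020 nM. Compound 1 sits at one end of this narrow spread, yet both compound 2 and compound 3 lie within the usual scatter of it, so the three numbers cannot be told apart with confidence.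

The next compound, compound 4, `N=C(N)c1ccc(-c2ccc(-c3ccc(F)cc3)o2)o1`, has not yet been measured. It differs from compound 1 in one place: fluoro in place of methoxy on an aromatic carbon. The change sits on an aromatic carbon of a six-membered aromatic ring of carbon only, para to a large group. Among the measured compounds shown here, no pair of measured compounds differs in only this way, so the size of the step has to be guessed rather than read off.

For the measured compounds named here, with no comparable step available, the expectation for the step from compound 1 to compound 4 in this assay is a 1.3-fold higher number from compound 1 to compound 4 (0.10 log units; within the scatter), that is, a change no larger than the usual scatter. Compound 4 is therefore expected to give about 2500 nM, within a range of 1000 nM to 6300 nM.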

Compound 4, concentration for 50% growth inhibition: 1730 nM
Compound 4: middle estimate off by 1.4-fold (0.16 log units), on the high side; the range from low to high includes it.
By their numbers in this assay, from the lowest: compounds 4, 1, 2 and 3 (each within the scatter of the next).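

Among the compounds shown here, putting fluoro in place of methoxy on this aromatic carbon, para to a large group, gives a 1.2-fold lower number from compound 1 to compound 4 (0.06 log units; within the scatter) in this assay, and this is the first direct reading of a change made in one place only. The swap takes away a methoxy of 2 heavy atoms and 1 hydrogen-bond acceptor and puts in a fluoro of 1 heavy atom and 0 hydrogen-bond acceptors, yet the numbers for compound 1 and compound 4 cannot be told apart. So, for this one pair, the oxygen-bearing methoxy is not needed at this position to keep growth inhibition at this level, though a single pair sets no general rule. Nothing measured here explains why the two compounds read alike.

The compounds shown leave open whether a very different group at the same place, such as an amine, a carboxylic acid or a longer chain like butoxy, would also leave the number within the scatter or would shift it clearly. They also leave open whether a plain hydrogen there would read the same as methoxy and fluoro.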